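The compounds below may be only part of what the source reports. "The series", "measured", "known", "first", "only" and "open" are said of these compounds alone.

Of the compounds shown here, three have been measured so far. Compound 1 `CCOCCn1c(N2CCN(CC)CC2)nc2ccccc21` gives 18 nM in a functional assay on ileum for inhibition of histamine H1 receptor (Cavia porcellus); a higher number here means a weaker inhibitor, a lower number a stronger inhibitor. Compound 2 `CCCN1CCN(c2nc3ccccc3n2CCOCC)CC1` gives 16 nM in this assay, and compound 3 `CCCCCCn1c(N2CCN(C)CC2)nc2ccccc21` gives 26 nM there. Compound 3 has the highest of the three numbers, yet its gap to compound 1 and its gap to compound 2 both lie within the scatter, so the three stand together. For the measured compounds named here, the one step between measured compounds, a 1.1-fold lower number from compound 1 to compound 2 (0.05 log units; within the scatter), concerns a methyl placed on a saturated chain carbon two bonds along the chain from an amine nitrogen in a ring, a different place from the one now in question.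

Compound 4 `CC(C)CCn1c(N2CCN(C)CC2)nc2ccccc21` differs from compound 3 in the chain on the aromatic nitrogen: isopropyl in place of butyl on a saturated chain carbon, two bonds along the chain from an aromatic nitrogen. Going by the values given here, no measured pair shows a change of this kind at this place, and the only step known, at another place, stayed within the scatter. The step of a 1.2-fold higher number from compound 3 to compound 4 (0.06 log units; within the scatter) is therefore expected to lie within the scatter. The estimate for compound 4 in this assay is 30 nM, with a range from 12 nM to 75 nM.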

Compound 4, half-maximal inhibitory concentration: 1400 nM
Compound 4: middle estimate off by 47-fold (1.67 log units), on the low side; measured number above the stated range.
By their numbers in this assay, from the lowest: compounds 2, 1 and 3 (each within the scatter of the next); then compound 4.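

Compound 3 carries a hexyl chain and compound 4 an isopentyl chain, and in this assay this single change gives a 54-fold higher number from compound 3 to compound 4 (1.73 log units; beyond the scatter) and so moves the number far beyond the scatter. For the compounds shown here, the place on a saturated chain carbon, two bonds along the chain from an aromatic nitrogen, is therefore highly sensitive to isopropyl in place of butyl, which the only earlier step, a 1.1-fold lower number from compound 1 to compound 2 (0.05 log units; within the scatter) at another place, gave no sign of. Nothing available explains the size of this step.

This single pair cannot separate the branch from the shorter chain, and a straight pentyl chain on the same core would be needed to tell the two apart. Also open, going by these compounds, is how this chain would respond to an amine or a carboxylic acid placed in it.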